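Three Amides at the Assay Ceiling, a Fourth Expected There

The compounds below may be only part of what the source reports. "The series", "measured", "known", "first", "only" and "open" are said of these compounds alone.

Compound 1 `CC(=O)Nc1ccc2ncc(-c3cnn(C)c3)cc2n1` gives in a functional assay on A549 cells (Homo sapiens) for antiproliferative activity, read by MTT assay, with a stated time of 48 h (on this read-out lower numbers stand for stronger inhibition and higher numbers for weaker inhibition), only a limit, > 50000 nM.
Compound 2 `Cn1cc(-c2cnc3ccc(NC(=O)C4CC4)nc3c2)cn1` gives in this assay only a limit, > 50000 nM.
Compound 3 `Cn1cc(-c2cnc3ccc(NC(=O)c4ccc(F)cc4)nc3c2)cn1` gives in this assay only a limit, > 50000 nM.

The three measured compounds share one core and differ only in the group on the carbonyl carbon of the amide. None of them gives a number: each sits at the limit of > 50000 nM in this assay, at which 3 of the 3 values shown sit. Compound 3 can therefore not be placed above or below the other two. The steps a step that the two limits leave unreadable from compound 1 to compound 3 and a step that the two limits leave unreadable from compound 2 to compound 3 bear on it, and both are unreadable, as is a step that the two limits leave unreadable from compound 1 to compound 2.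

Compound 4 `COc1ccc(C(=O)Nc2ccc3ncc(-c4cnn(C)c4)cc3n2)cc1` differs from compound 3 by methoxy in place of fluoro on an aromatic carbon. With every measured step unreadable, no direction can be drawn for this assay. The expected step is a number no higher from compound 3 to compound 4 (the limit leaves the size open), most likely ending again at a limit. Compound 4 is expected to give 50000 nM, in a range from 15000 nM to 150000 nM.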

Compound 4, half-maximal inhibitory concentration: 6400 nM
Compound 4: middle estimate off by 7.8-fold (0.89 log units), on the high side; measured number outside the range, below it.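

In this assay, methoxy in place of fluoro on the aromatic carbon, para to a large group, gives an at least 7.8-fold lower number from compound 3 to compound 4 (0.89 log units; beyond the scatter), so an aromatic ring on the carbonyl carbon is not enough by itself to bring a readable number. The 4-methoxyphenyl group also stands apart from the two smaller groups, with an at least 7.8-fold lower number from compound 2 to compound 4 (0.89 log units; beyond the scatter) and an at least 7.8-fold lower number from compound 1 to compound 4 (0.89 log units; beyond the scatter). Each size is only a minimum, since the earlier compounds give no number: the limit of > 50000 nM in this assay, at which 3 of the 4 values shown sit.

The steps among compound 1, compound 2 and compound 3 remain unreadable. Going by these compounds, whether ethoxy or an amine at this place would match methoxy stays open.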